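The compounds below may be only part of what the source reports. "The series", "measured", "known", "first", "only" and "open" are said of these compounds alone.

Measured so far in a functional assay on KB cells (Homo sapiens) for antiproliferative activity, read by sulforhodamine B assay, with a stated time of 3 days; a lower number here means that less compound is needed, a higher number that more compound is needed for the effect:
- compound 1, `CCC1=C(O)c2c(oc(-c3ccc(C)cc3)cc2=O)C(CC)(CC)C1=O`, gives 39.2 uM.
- compound 2, `CCOc1ccc(-c2cc(=O)c3c(o2)C(CC)(CC)C(=O)C(CC)=C3O)cc1`, is reported only as a limit of this assay, > 52.4 uM.
- compound 3, `CCC1=C(O)c2c(oc(-c3ccccc3OC)cc2=O)C(CC)(CC)C1=O`, gives 40.8 uM.

Compound 1 holds the lower of the two numbers, and compound 3 sits beside it, the step being a 1.0-fold higher number from compound 1 to compound 3 (0.02 log units; within the scatter). Compound 2 sits at the limit described by the limit of > 52.4 uM in this assay, at which 1 of the 3 values shown sits, so that an at least 1.3-fold higher number from compound 1 to compound 2 (0.12 log units; that floor lies within the scatter) is known only as a floor.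

The next compound is compound 4, `CCC1=C(O)c2c(oc(-c3cc(C)c(C)cc3C)cc2=O)C(CC)(CC)C1=O`. It differs from compound 1 in one place: 2,4,5-trimethylphenyl in place of 4-methylphenyl on an aromatic carbon. The measured steps that bear on it are the two changes of the aryl group on the same aromatic carbon, a 1.0-fold higher number from compound 1 to compound 3 (0.02 log units; within the scatter) and an at least 1.3-fold higher number from compound 1 to compound 2 (0.12 log units; that floor lies within the scatter); neither moved this assay beyond the scatter, though compound 2 shows that a limit is possible. The added methyl groups on the phenyl ring of compound 4 are a larger change than either of those, but nothing measured here points in one direction or the other. Compound 4 is therefore expected to stay close to compound 1, with a 1.1-fold higher number from compound 1 to compound 4 (0.03 log units; within the scatter) as the estimated step. The estimate for compound 4 is 42 uM, with a range from 22 uM to 80 uM.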

Compound 4, concentration for half-maximal effect: 8.2 uM
Compound 4: the middle estimate sits 5.1-fold (0.71 log units) above what was measured, and the stated range ends above it.
By their numbers in this assay, from the lowest: compound 4; then compounds 1 and 3 (each within the scatter of the next). At a limit, above all of these: compound 2.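

In this assay, the aryl group on the aromatic carbon next to the ring oxygen proved able to move the number beyond the scatter, which the earlier changes at this position had not shown: the replacement of 4-methylphenyl by 2,4,5-trimethylphenyl gives a 4.8-fold lower number from compound 1 to compound 4 (0.68 log units; beyond the scatter), and the replacement of 2-methoxyphenyl gives a 5.0-fold lower number from compound 3 to compound 4 (0.70 log units; beyond the scatter). The change goes from 7 to 9 heavy atoms, all carbon, with 0 hydrogen-bond donors and 0 hydrogen-bond acceptors on either group, so a step of this size at this position needs no such atoms in the entering group. The comparison with the remaining compound is an at least 6.3-fold lower number from compound 2 to compound 4 (0.80 log units; beyond the scatter), a floor beyond the scatter that rests on a limit: the limit of > 52.4 uM in this assay, at which 1 of the 4 values shown sits.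

What stays open is which of the added methyl groups accounts for the step, as they enter together in compound 4. Also open, going by these compounds, is how this position would respond to an amine, a carboxylic acid or a longer chain on the phenyl ring, and whether the shared core tolerates such groups in this assay.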